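One Aryl Exchange in a Series of Low Growth Inhibition

The source may hold more compounds than are shown below. What is called first, only, known or untested is meant among the compounds shown, and "the series" means these compounds.

Of the compounds shown here, three sharing one core have been tested in a functional assay on MIA PaCa-2 cells (Homo sapiens) for inhibition, read by MTT assay, with a stated time of 48 h, tested at 10 uM; a higher number here means more inhibition of growth at the concentration tested, a lower number less inhibition of growth. There, compound 1 (`Cc1cc(=O)c2c(O)cc(OCc3ccc(Br)cc3)c([C@H]3CCN(C)C[C@H]3O)c2o1`) gives 13%, compound 2 (`CCOC(=O)N1CCN(Cc2c(O)c([C@H]3CCN(C)C[C@H]3O)c3oc(C)cc(=O)c3c2O)CC1`) gives 4% and compound 3 (`Cc1oc2c([C@H]3CCN(C)C[C@H]3O)c(O)cc(O)c2c(=O)c1C(O)c1cccc(Cl)c1`) gives 2%. Compound 3 and compound 2 lie within the scatter of each other, while compound 1 stands above compound 3 by more than the scatter.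

Compound 4 (`COc1ccc(C(O)c2c(C)oc3c([C@H]4CCN(C)C[C@H]4O)c(O)cc(O)c3c2=O)cc1Br`) has yet to be measured in this assay. It differs from compound 3 in a single place: 3-bromo-4-methoxyphenyl in place of 3-chlorophenyl on a saturated chain carbon bound to an aromatic carbon and an oxygen on a saturated carbon. In words, 3-bromo-4-methoxyphenyl stands in place of 3-chlorophenyl on a saturated chain carbon bound to an aromatic carbon and an oxygen on a saturated carbon.

Among the measured compounds shown here, no two tested compounds differ in only one place, so the data give no direct measure of such a change. The expectation rests instead on the low range of the series, which runs from compound 3 at 2% to compound 1 at 13%. No change beyond the scatter is expected in either direction, and the estimated step of a number 4 percentage points higher from compound 3 to compound 4 (within the scatter) is small. Compound 4 is estimated at 6%, with an expected range of 0% to 18%.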

Compound 4, percent growth inhibition at one concentration: 3%
Beside the measured number, compound 4's estimate is 3 percentage points above it; the measured number falls inside the stated range.
By their numbers in this assay, from the lowest: compounds 3, 4, 2 and 1 (each within the scatter of the next, the first and the last beyond it).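

Among the compounds shown here, the pair of compound 3 and compound 4 is the first to differ in one place, and so it gives the first direct reading of a change at this position. In this assay, 3-bromo-4-methoxyphenyl in place of 3-chlorophenyl on a saturated chain carbon bound to an aromatic carbon and an oxygen on a saturated carbon gives a number 1 percentage points higher from compound 3 to compound 4 (within the scatter), so this position tolerates a larger aryl group, with 9 heavy atoms against 7 and 1 hydrogen-bond acceptor against 0, without a reading beyond the scatter. Nothing at hand explains this outcome or connects it to any property of either group.

Both aryl groups shown are six-membered aromatic rings of carbon only that carry a halogen, so it stays open whether a phenyl group bearing an amine or a carboxylic acid, or a longer saturated chain in place of the aryl group, would give a different reading at this position. From the compounds shown here alone, it also stays open whether the hydroxy group on the chain carbon matters, as the (hydroxy)methyl unit is the same in both compounds of the pair.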